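The source may hold more compounds than are shown below. What is called first, only, known or untested is meant among the compounds shown, and "the series" means these compounds.

Measured in a functional assay on MDA-MB-231 cells (Homo sapiens) for cytotoxicity, read by MTT assay, with a stated time of 48 h; a higher number here means a weaker inhibitor, a lower number a stronger inhibitor:
- compound 1 `COc1ccc(C2=NOC(COc3ccc(-c4nnnn4-c4cc(OC)c(OC)c(OC)c4)cc3N)C2)cc1OC`: 3570 nM
- compound 2 `COc1ccc(F)c(C2=NOC(COc3ccc(-c4nnnn4-c4cc(OC)c(OC)c(OC)c4)cc3N)C2)c1`: 2830 nM

Compound 2 and compound 1 lie within the scatter of each other, so neither can be ranked above the other. Compound 3 `COc1cc(-n2nnnc2-c2ccc(OCC3CC(c4ccccc4F)=NO3)c(N)c2)cc(OC)c1OC` changes compound 2 in one place: hydrogen in place of methoxy on an aromatic carbon. Hydrogen stands in place of methoxy on an aromatic carbon, turning 2-fluoro-5-methoxyphenyl into 2-fluorophenyl. Among the measured compounds shown here, the only measured step, a 1.3-fold lower number from compound 1 to compound 2 (0.10 log units; within the scatter), also altered this phenyl group and stayed within the scatter. The expected step is therefore small, with none beyond the scatter: a 1.1-fold higher number from compound 2 to compound 3 (0.03 log units; within the scatter). Compound 3 is estimated at 3000 nM, with an expected range of 1300 nM to 7000 nM.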

Compound 3, half-maximal inhibitory concentration: 2400 nM
Compound 3: middle estimate off by 1.3-fold (0.10 log units), on the high side; the measured number falls inside the stated range.
By their numbers in this assay, from the lowest: compounds 3, 2 and 1 (each within the scatter of the next).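

In this assay, hydrogen in place of methoxy on the aromatic carbon para to the fluoro group gives a 1.2-fold lower number from compound 2 to compound 3 (0.07 log units; within the scatter), so this methoxy group is not needed to hold the number at this level. Replacing 3,4-dimethoxyphenyl with 2-fluorophenyl gives a 1.5-fold lower number from compound 1 to compound 3 (0.17 log units; within the scatter), so a phenyl group with no methoxy at all also stays within the scatter. No measurement is available to explain this result. Still open, on these data alone, is whether a hydroxy group, an amine or a longer chain such as ethoxy on this carbon would give a step beyond the scatter.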